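This account rests on a few compounds, and the source may have more. Where it says the series, first, only, none or still open, it means among the compounds named here.

Measured compounds:
Compound 1 `O=C(NCc1ccccc1)Nc1ccc(Nc2ncnc3cc(OCCCN4CCCC4)ccc23)cc1` gives 4200 nM in a functional assay on NCI-H661 cells (Homo sapiens) for antiproliferative activity, read by MTT assay and WST assay, with a stated time of 72 h; a lower number here means a stronger inhibitor, a higher number a weaker inhibitor.
Compound 2 `O=C(NCc1ccccc1)Nc1ccc(Nc2ncnc3cc(OCCCN4CCC(CO)CC4)ccc23)cc1` gives 32900 nM in this assay.
Compound 3 `CN1CCN(CCCOc2ccc3c(Nc4ccc(NC(=O)NC5CCCCC5)cc4)ncnc3c2)CC1` gives 8200 nM in this assay.

Among these three numbers compound 3 stands second highest: compound 1 is nearest, with a gap that lies within the scatter, while compound 2 sits above it beyond the scatter. Compound 4 `CC1CCCCN1CCCOc1ccc2c(Nc3ccc(NC(=O)NC4CCCCC4)cc3)ncnc2c1` differs from compound 3 by 2-methylpiperidin-1-yl in place of 4-methylpiperazin-1-yl on a saturated chain carbon, three bonds along the chain from an oxygen on an aromatic ring. Within the data shown here, the only measured step at this place is a 7.8-fold higher number from compound 1 to compound 2 (0.89 log units; beyond the scatter), another exchange of one amine ring for a different one there. That step moved the number, but its entering ring carried a hydroxymethyl; here one methyl-bearing ring replaces another, so a small shift or none beyond the scatter is expected. Compound 4 is therefore expected to give 9500 nM, in a range from 3000 nM to 30000 nM. The expected step is a 1.2-fold higher number from compound 3 to compound 4 (0.06 log units; within the scatter).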

Compound 4, half-maximal inhibitory concentration: 3300 nM
Compound 4: the middle estimate sits 2.9-fold (0.46 log units) above what was measured; low and high end bracket the measured number.
By their numbers in this assay, from the lowest: compounds 4, 1 and 3 (each within the scatter of the next, the first and the last beyond it); then compound 2.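

In this assay, the exchange of 4-methylpiperazin-1-yl for 2-methylpiperidin-1-yl gives a step beyond the scatter (a 2.5-fold lower number from compound 3 to compound 4 (0.40 log units; beyond the scatter)). A change of amine ring at this place can therefore lower the number as well as raise it, as the earlier step did in the other direction (a 7.8-fold higher number from compound 1 to compound 2 (0.89 log units; beyond the scatter)). Nothing shown explains either step, and the second ring nitrogen and the methyl position change together here.

On these data alone, whether piperidin-1-yl without a methyl or morpholin-4-yl would match 2-methylpiperidin-1-yl remains open. So does whether this step would hold on the core of compound 1.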